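The compounds below may be only part of what the source reports. "The series", "measured", "known", "first", "only" and "open" are said of these compounds alone.

Compound 1 `CN1CCCc2ccc(NC(=O)c3ccc(-c4ccccc4)cc3)cc21` stands second highest of the three numbers in a functional assay for antagonist activity at transient receptor potential cation channel subfamily V member 1 (Homo sapiens), read by FLIPR and calcium flux (a lower number here means a less potent compound, a higher number a more potent compound, by a factor of ten per unit of this negative logarithm), where compound 1 gives 7.5. Compound 2 `O=C(Nc1ccc2c(c1)NCCC2)c1ccc(-c2ccccc2)cc1` gives 7.7 in this assay, and the step of a number 0.20 log units higher from compound 1 to compound 2 (within the scatter) is within the scatter, so no order between these two is claimed. Compound 3 `CC(=O)NCCN1CCCc2ccc(NC(=O)c3ccc(-c4ccccc4)cc3)cc21` gives 6.9 in this assay; the steps of a number 0.60 log units lower from compound 1 to compound 3 (beyond the scatter) and a number 0.80 log units lower from compound 2 to compound 3 (beyond the scatter) are both beyond the scatter and both go down. The change to compound 4 `CNS(=O)(=O)c1cccc(-c2ccc(C(=O)Nc3ccc4c(c3)N(C)CCC4)cc2)c1` is methylsulfamoyl in place of hydrogen on an aromatic carbon, the new group entering meta to a large group. Among the compounds with values here, none of the measured steps bears on this change: all three touch only the ring nitrogen of the shared core or the chain attached to it, and nothing measured tells how this aromatic carbon responds to substitution. Within the data shown here, with no comparable step, no movement beyond the scatter is expected in either direction. The number for compound 4 is estimated at 7.5 with a range of 6.8 to 8.2. That estimate corresponds to an expected step of no change at the digits printed from compound 1 to compound 4 (within the scatter).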

Compound 4, negative logarithm of the antagonist equilibrium constant: 7
Compound 4: the middle estimate sits 0.50 log units above what was measured; the range from low to high includes it.
By their numbers in this assay, from the lowest: compounds 3 and 4 (each within the scatter of the next); then compounds 1 and 2 (each within the scatter of the next).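

Within the data shown here, the aromatic carbon, which no earlier step touched, is not indifferent to substitution: in this assay methylsulfamoyl in place of hydrogen gives a number 0.50 log units lower from compound 1 to compound 4 (beyond the scatter), the first reading of a change away from the ring nitrogen of the shared core and the chain on it. The step is modest, and compound 4 still gives a measurable number, so this position accepts a group of 5 heavy atoms with some loss. No measurement on hand accounts for this step.

A single substituent leaves open whether the loss belongs to methylsulfamoyl or to any group on this carbon. Also open, as far as these compounds go, are how a carboxylic acid, an amine or a simple methyl on the same carbon would read, and whether methylsulfamoyl behaves alike on the core of compound 2.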